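Trifluoromethoxy for Trifluoromethyl on the Aryl Sulfur Substituent

A few compounds are considered here, and "the series" means these few. Any claim that something is new, unique, unknown or untested is made for them only; others in the source may bear on it.

In a functional assay on LNCaP cells (Homo sapiens) for antiproliferative activity, read by propidium iodide staining, with a stated time of 96 h (a higher number here means a weaker inhibitor, a lower number a stronger inhibitor), three compounds have been measured:
compound 1, `CC(O)(CSc1cccc(C(F)(F)F)c1)C(=O)Nc1cccc(S(F)(F)(F)(F)F)c1`, gives 12700 nM;
compound 2, `CC(O)(CSc1ccccc1C(F)(F)F)C(=O)Nc1cccc(S(F)(F)(F)(F)F)c1`, gives 12300 nM;
compound 3, `CC(O)(CSc1cccc(OC(F)(F)F)c1)C(=O)Nc1cccc(S(F)(F)(F)(F)F)c1`, gives 10900 nM.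

All three share one core and differ only in the aryl group on the sulfur. The change 2-(trifluoromethyl)phenyl in place of 3-(trifluoromethyl)phenyl on a sulfur gives a 1.0-fold lower number from compound 1 to compound 2 (0.01 log units; within the scatter). The change trifluoromethoxy in place of trifluoromethyl on an aromatic carbon gives a 1.2-fold lower number from compound 1 to compound 3 (0.07 log units; within the scatter). Neither move reaches beyond the scatter, so the three numbers cannot be ordered.

Compound 4, `CC(O)(CSc1ccccc1OC(F)(F)F)C(=O)Nc1cccc(S(F)(F)(F)(F)F)c1`, is not yet measured. It differs from compound 2 by trifluoromethoxy in place of trifluoromethyl on an aromatic carbon. This is the same kind of change as that from compound 1 to compound 3, but the place differs: there the group is meta to a large group, here it is ortho to a large group. Within the data shown here, the closest precedent is the step from compound 1 to compound 3, which stayed within the scatter, so compound 4 is expected to show a 1.1-fold lower number from compound 2 to compound 4 (0.03 log units; within the scatter). On that basis compound 4 is estimated to give 11500 nM in this assay, with a likely range from 6000 nM to 22000 nM.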

Compound 4, half-maximal inhibitory concentration: 10000 nM
Compound 4: the middle estimate sits 1.2-fold (0.06 log units) above what was measured; low and high end bracket the measured number.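

In this assay, trifluoromethoxy in place of trifluoromethyl on an aromatic carbon, here ortho to a large group, gives a 1.2-fold lower number from compound 2 to compound 4 (0.09 log units; within the scatter). Set beside the earlier step, the change behaves alike on the two cores, with the gap between the two steps within the scatter: the same change on two cores in this assay, a 1.2-fold lower number (0.07 log units; within the scatter) from compound 1 to compound 3 and a 1.2-fold lower number (0.09 log units; within the scatter) from compound 2 to compound 4, 1.1-fold (0.02 log units) apart, within the scatter of two such steps. This shows that the change carries from one of these two cores to the other without a detectable shift, but neither step rises above the scatter, so it shows no real gain from the change, and the two cores differ only in the aryl group on the sulfur, so it says nothing about cores altered elsewhere.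

The compounds shown leave open whether a methoxy group or a nitrile in place of either fluorinated group would move the number beyond the scatter. They also leave open what happens to the change when the sulfur carrying the aryl group is replaced by a sulfonyl.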